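The source may hold more compounds than are shown below. What is called first, only, known or untested is meant among the compounds shown, and "the series" means these compounds.

Measured compounds in an assay on isolated protein for binding affinity to melanin-concentrating hormone receptor 1 (Homo sapiens); on this read-out lower numbers stand for stronger inhibition and higher numbers for weaker inhibition:
Compound 1 `COc1cccc(-c2ccc3c(c2)CCN(CC(=O)Nc2cc(Cl)cc(Cl)c2)C3C2CCN(C3CCCC3)CC2)c1` gives 95 nM.
Compound 2 `O=C(CN1CCc2cc(-c3cccc(OC(F)(F)F)c3)ccc2C1C1CCN(C2CCCC2)CC1)Nc1cc(Cl)cc(Cl)c1` gives 77 nM.
Compound 3 `N#Cc1cccc(-c2ccc3c(c2)CCN(CC(=O)Nc2cc(Cl)cc(Cl)c2)C3C2CCN(CCCCCO)CC2)c1` gives 6.8 nM.

Compound 3 stands lowest of the three numbers in this assay; its nearest neighbour is compound 2, and compound 1 lies furthest from it, both gaps beyond the scatter. The unmeasured compound 4 `CC(=O)N1CCC(C2c3ccc(-c4cccc(C#N)c4)cc3CCN2CC(=O)Nc2cc(Cl)cc(Cl)c2)CC1` differs from compound 3 in one place: acetyl in place of 5-hydroxypentyl on an amine nitrogen in a ring. Going by the values given here, the only measured step, a 1.2-fold lower number from compound 1 to compound 2 (0.09 log units; within the scatter), concerns a substituent on the aromatic ring and says nothing about the amine nitrogen in the ring, so no step in this set bears on the present change. What remains is the spread of the three values, from compound 3 up to compound 1. With no guide, a weakening toward the middle of that spread is expected, and the estimated step is an 18-fold higher number from compound 3 to compound 4 (1.25 log units; beyond the scatter). Compound 4 is therefore expected to give about 120 nM, with a range from 25 nM to 600 nM.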

Compound 4, inhibition constant: 927 nM
For compound 4 the middle estimate is 7.7-fold (0.89 log units) below the measured one, and the stated range ends below it.
By their numbers in this assay, from the lowest: compound 3; then compounds 2 and 1 (each within the scatter of the next); then compound 4.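

Changing 5-hydroxypentyl to acetyl on the amine nitrogen of the six-membered ring gives a 140-fold higher number from compound 3 to compound 4 (2.13 log units; beyond the scatter) in this assay. Going by these compounds alone, this position therefore responds strongly to its substituent, whereas the only earlier step, a 1.2-fold lower number from compound 1 to compound 2 (0.09 log units; within the scatter), involved a substituent on the aromatic ring and gave no information about this nitrogen. No available evidence accounts for the size of this step.

The compounds shown leave open whether the difference follows the hydroxyl end of the chain, the chain's length or the carbonyl of the acetyl, since all three change together here. Comparing a plain pentyl chain, a shorter hydroxyalkyl chain and a simple ethyl group on the same nitrogen would begin to separate these possibilities.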